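The compounds below may be only part of what the source reports. "The series", "measured", "known", "first", "only" and "open" are said of these compounds alone.

Measured compounds in a functional assay on the whole organism for antagonist activity, with Rattus norvegicus as the target; a lower number here means that less compound is needed, a higher number that more compound is needed for the effect:
- compound 1 `c1nc(NC2CC2)c2ncn(CC3CCC3)c2n1`: 10 mg/kg
- compound 2 `c1nc(NC2CC2)c2ncn(CC3CCCC3)c2n1`: 15 mg/kg
- compound 3 `CC(C1CC1)n1cnc2c(NC3CC3)ncnc21`: 2 mg/kg; 4.5 mg/kg; 12.5 mg/kg (3 entries)

On the numbers shown, compound 2 sits at the upper end of the two single values, but its gap to compound 1, a 1.5-fold higher number from compound 1 to compound 2 (0.18 log units; within the scatter), stays within the scatter, so the two are not separated. Compound 3 carries no single number; its repeat entries, (the several entries of compound 3 in this assay, 2 mg/kg; 4.5 mg/kg; 12.5 mg/kg (3 entries)), spread over a range that itself illustrates how far repeats of this assay can drift.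

The change to compound 4 `c1nc(NC2CC2)c2ncn(C3CC3)c2n1` is cyclopropyl in place of cyclopentylmethyl on an aromatic nitrogen. Among the measured compounds shown here, only one measured step touches the group on the aromatic nitrogen, namely a 1.5-fold higher number from compound 1 to compound 2 (0.18 log units; within the scatter), and it is within the scatter; that step kept the saturated chain carbon and changed only the ring, whereas here the chain carbon is lost and the ring shrinks, so there is no direct precedent. For the measured compounds named here, with the sole relevant step flat and the repeats of compound 3 wide, no shift beyond the scatter is expected in this assay, and the estimate is given a correspondingly broad range.

The expected step, a 1.3-fold lower number from compound 2 to compound 4 (0.10 log units; within the scatter), is taken as flat. Compound 4 is expected to give 12 mg/kg, with a range from 4 mg/kg to 35 mg/kg.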

Compound 4, dose for half-maximal effect: 4.5 mg/kg
The estimate for compound 4 lay 2.7-fold (0.43 log units) above the measured number; the range from low to high includes it.
By their numbers in this assay, from the lowest: compound 4; then compounds 1 and 2 (each within the scatter of the next).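

In this assay, the group on the aromatic nitrogen now gives steps beyond the scatter, which the exchange of cyclobutyl for cyclopentyl on the saturated chain carbon did not: cyclopropyl in place of cyclopentylmethyl gives a 3.3-fold lower number from compound 2 to compound 4 (0.52 log units; beyond the scatter), and cyclopropyl in place of cyclobutylmethyl gives a 2.2-fold lower number from compound 1 to compound 4 (0.35 log units; beyond the scatter). Both changes point the same way, so this position responds when the chain carbon is lost and the ring shrinks together, with less compound needed for the effect in compound 4. Both steps are modest, however, and repeat entries for a compound with the same shared core spread widely, so the shift is a lead rather than a firm ranking: the several entries of compound 3 in this assay, 2 mg/kg; 4.5 mg/kg; 12.5 mg/kg (3 entries)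

The compounds shown do not separate loss of the chain carbon from the change in ring size, and cyclopropylmethyl on the same nitrogen would be the direct test of that. Going by these compounds, it also remains open how this position would respond to an open chain such as ethyl or to a chain carrying an amine or a carboxylic acid.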